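The source may hold more compounds than are shown below. What is called first, only, known or untested is meant among the compounds shown, and "the series" means these compounds.

Compound 1 `Cn1nc(N)c2c(=O)[nH]c(-c3ccccc3)cc21` gives 6% in an assay on isolated protein for inhibition of protein kinase C zeta type (Homo sapiens), read by mobility shift assay, tested at 30 uM; on this read-out lower numbers stand for less inhibition and higher numbers for more inhibition at the one concentration tested (going by the name of the read-out).
Compound 2 `Cn1nc(N)c2c(=O)[nH]c(-c3ccccn3)cc21` gives 0% in this assay.
Compound 3 `Nc1c2c(=O)[nH]c(-c3ccccc3)cc2nn1-c1ccccc1` gives -163% in this assay.

Compound 1 and compound 2 share one core and differ in a single place, (pyridin-2-yl in place of phenyl on an aromatic carbon), and that change moved the read-out by a number 6 percentage points lower from compound 1 to compound 2 (within the scatter). Compound 3 is built on a different core; the difference between the two cores is not broken down here. In this assay compound 3 gives -163%, far from the other two.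

Compound 4 `Nc1c2c(=O)[nH]c(-c3ccccn3)cc2nn1-c1ccccc1` has not yet been measured. It differs from compound 3 by pyridin-2-yl in place of phenyl on an aromatic carbon, the same change that took compound 1 to compound 2. Because that change produced a number 6 percentage points lower from compound 1 to compound 2 (within the scatter), the step from compound 3 to compound 4 is expected to be small, estimated at a number 2 percentage points lower from compound 3 to compound 4 (within the scatter). Compound 4 is therefore expected to give about -165%, somewhere between -240% and -80%.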

Compound 4, a percentage reported as inhibition, at one concentration (the size of the read-out at that concentration, not a potency): 3%
Compound 4: middle estimate off by 168 percentage points, on the low side; measured number above the stated range.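

In this assay, putting pyridin-2-yl in place of phenyl on the core of compound 3 gave a number 166 percentage points higher from compound 3 to compound 4 (beyond the scatter). This shows that the effect of this change cannot simply be carried from one core to the other in this series, as setting the two steps side by side makes plain: the same change on two cores in this assay, a number 6 percentage points lower (within the scatter) from compound 1 to compound 2 and a number 166 percentage points higher (beyond the scatter) from compound 3 to compound 4, 172 percentage points apart, beyond the scatter of two such steps It does not show why the cores differ, and the large step rests on a single reading for compound 3 of -163%.

Still open, going by these compounds, is how a carboxylic acid or an amine in that same place would read on either core. Also open, on these data alone, is how the change would behave on a third core.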